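The compounds below may be only part of what the source reports. "The series", "measured", "known", "first", "only" and "open" are said of these compounds alone.

Measured compounds: compound 1 `O=C(O)Cn1c(SCCOc2cccc3ccccc23)nc2ccccc21` with 2000 nM; compound 2 `O=C(O)Cn1c(SCCCOc2ccccc2)nc2ccccc21` with 786 nM; compound 3 `O=C(O)Cn1c(SCCCCOc2ccccc2)nc2ccccc21` with 1400 nM.

All three were tested in an assay on HEK293 cells for displacement of a labelled ligand from prostaglandin D2 receptor 2 (Homo sapiens); on this read-out higher numbers stand for weaker inhibition and lower numbers for stronger inhibition. Compound 2 gives 786 nM, the lowest number of the three, but its gap to compound 3 is within the scatter, so the two cannot be told apart; only compound 1, at 2000 nM, stands clearly beyond it.

The untested compound 4 `O=C(O)Cn1c(SCCc2ccccc2)nc2ccccc21` differs from compound 2 in one place: phenyl in place of phenoxymethyl on a saturated chain carbon, two bonds along the chain from a sulfur. The chain that links the sulfur to the aromatic ring is thus shortened and its oxygen is removed.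

Within the data shown here, only one measured step touches this part of the molecule, a 1.8-fold higher number from compound 2 to compound 3 (0.25 log units; within the scatter), which lengthens the same chain by one carbon and changes little. Among the measured compounds shown here, no measured pair removes the oxygen or shortens the chain, so the step to compound 4 is not covered by a direct comparison; compound 1, which carries a different ring on a shorter oxygen-containing chain, gives a higher number than compound 2 but changes two things at once.

Given this, compound 4 is expected to sit near compound 2 or somewhat higher, with a step of about a 1.9-fold higher number from compound 2 to compound 4 (0.28 log units; within the scatter). The estimate for compound 4 is 1500 nM, within a range from 500 nM to 5000 nM.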

Compound 4, half-maximal inhibitory concentration: 881 nM
Compound 4: the middle estimate sits 1.7-fold (0.23 log units) above what was measured; the measured number falls inside the stated range.
By their numbers in this assay, from the lowest: compounds 2, 4, 3 and 1 (each within the scatter of the next, the first and the last beyond it).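

In this assay, putting phenyl in place of phenoxymethyl on a saturated chain carbon, two bonds along the chain from a sulfur, gives a 1.1-fold higher number from compound 2 to compound 4 (0.05 log units; within the scatter), so this read-out cannot tell the two compounds apart. Among these compounds, this is the first measured pair in which the chain oxygen is gone, and with phenyl the hydrogen-bond acceptor counted in phenoxymethyl is gone too, yet for this pair the number stays within the scatter; the oxygen is therefore not needed to reach a value of this size when the chain is also shortened. Two single changes now start from compound 2, the other being a 1.8-fold higher number from compound 2 to compound 3 (0.25 log units; within the scatter), and neither can be told from the scatter, while nothing available explains why this part of the molecule tolerates both.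

From the compounds shown here alone, removing the oxygen and shortening the chain happen together here, and what each does alone stays open, as does the value of an all-carbon chain ending in phenyl and matching the chain length of compound 2. Also open, going by these compounds, is what an amine nitrogen in place of the chain oxygen, or a fluorine on the phenyl ring, would do to the number.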